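The source may hold more compounds than are shown below. What is called first, only, known or untested is meant among the compounds shown, and "the series" means these compounds.

Measured in a functional assay on NCI-H460 cells (Homo sapiens) for inhibition, with a stated time of 72 h; a higher number here means a weaker inhibitor, a lower number a stronger inhibitor:
- compound 1 `COc1ccc(S(=O)(=O)N2CCc3cccc(-c4ccc(F)nc4)c32)cc1`: 135 nM
- compound 2 `COc1ccc(S(=O)(=O)N2CCc3cccc(-c4ccco4)c32)cc1`: 94.5 nM

Among the compounds with values here, compound 1 holds the higher of only two numbers, but the gap does not separate it from the other measured compound: a 1.4-fold lower number from compound 1 to compound 2 (0.15 log units; within the scatter). No order can be drawn from this pair.

The next compound is compound 3 `COc1ccc(S(=O)(=O)N2CCc3cccc(-c4cccc(F)c4)c32)cc1`, and the change is 3-fluorophenyl in place of 6-fluoropyridin-3-yl on an aromatic carbon. Within the data shown here, the only measured step bearing on this is the one above, where furan-2-yl takes the place of the same 6-fluoropyridin-3-yl on the same aromatic carbon. It stays within the scatter, but it is a single step and involves a different incoming group. No step beyond the scatter is therefore expected in this assay, and no direction is favoured. The expected step is a 1.1-fold lower number from compound 1 to compound 3 (0.05 log units; within the scatter). For compound 3 the estimated value is 120 nM, with an expected range of 50 nM to 300 nM.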

Compound 3, half-maximal inhibitory concentration: 167 nM
For compound 3 the middle estimate is 1.4-fold (0.14 log units) below the measured one, and the stated range covers the measured number.
By their numbers in this assay, from the lowest: compounds 2, 1 and 3 (each within the scatter of the next).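

In this assay, the exchange of a six-membered aromatic ring with 1 hetero atom for one of carbon only, with the fluorine retained, stays within the scatter (a 1.2-fold higher number from compound 1 to compound 3 (0.09 log units; within the scatter)), so the ring nitrogen of 6-fluoropyridin-3-yl shows no measurable contribution at this aromatic carbon. The comparison of the five-membered furan-2-yl with 3-fluorophenyl also stays within the scatter (a 1.8-fold higher number from compound 2 to compound 3 (0.25 log units; within the scatter)), leaving the three aromatic groups in this series without a resolved order. No accompanying data account for these small steps.

Going by these compounds, it remains open whether a non-aromatic group at this carbon, such as morpholine, a carboxylic acid or a short alkyl chain, would produce a step beyond the scatter. On these data alone, the role of the methoxy group on the sulfonyl-bearing ring also remains open.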